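This account rests on a few compounds, and the source may have more. Where it says the series, first, only, none or still open, it means among the compounds named here.

Compound 1 `CC(=O)OC[C@H]1O[C@@H](n2c(SCc3cc4cc(F)ccc4oc3=O)nc3cncnc32)[C@H](OC(C)=O)[C@@H]1OC(C)=O` was tested in a functional assay on Huh-5-2 cells (Homo sapiens) for cytotoxicity, read by microscopy (a higher number here means that more compound is tolerated, a lower number that less compound is tolerated), and gave 7600 nM. Compound 2 `CC(=O)OC[C@H]1O[C@@H](n2c(SCc3cc4cc(Cl)ccc4oc3=O)nc3cncnc32)[C@H](OC(C)=O)[C@@H]1OC(C)=O` differs from it only by chloro in place of fluoro on an aromatic carbon, and in this assay compound 2 gave 7500 nM, so that the step of a 1.0-fold lower number from compound 1 to compound 2 (0.01 log units; within the scatter). Compound 3 `O=c1oc2ccc(F)cc2cc1CSc1nc2cncnc2n1[C@@H]1O[C@H](CO)[C@@H](O)[C@H]1O` carries a different core; the difference between the two cores is not broken down here. In this assay compound 3 gave 36000 nM, a higher number than either compound 1 or compound 2. Compound 4 `O=c1oc2ccc(Cl)cc2cc1CSc1nc2cncnc2n1[C@@H]1O[C@H](CO)[C@@H](O)[C@H]1O` is not yet measured; it differs from compound 3 by chloro in place of fluoro on an aromatic carbon, the same change that leads from compound 1 to compound 2. Because that earlier step a 1.0-fold lower number from compound 1 to compound 2 (0.01 log units; within the scatter), compound 4 is expected to stay close to compound 3, with an estimated step of no change at the digits printed from compound 3 to compound 4 (within the scatter). The estimate for compound 4 in this assay is therefore 36000 nM, expected to lie between 18000 nM and 72000 nM.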

Compound 4, half-maximal cytotoxic concentration: 37000 nM
Estimate against measurement, compound 4: 1.0-fold (0.01 log units) below; the measured number falls inside the stated range.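

In this assay, the step for chloro in place of fluoro on the core of compound 3 is a 1.0-fold higher number from compound 3 to compound 4 (0.01 log units; within the scatter). Set beside the earlier step on the other core, the swap reads the same on both: the same change on two cores in this assay, a 1.0-fold lower number (0.01 log units; within the scatter) from compound 1 to compound 2 and a 1.0-fold higher number (0.01 log units; within the scatter) from compound 3 to compound 4, 1.0-fold (0.02 log units) apart, within the scatter of two such steps

So on these two cores, the choice between the two halogens makes no readable difference to how much compound the cells tolerate, but two pairs cannot show that this would hold on a third core or in any other kind of test. Only fluoro and chloro appear at this place on the aromatic ring. From the compounds shown here alone, whether an amine, a methoxy group or a carboxylic acid there would shift the tolerated concentration remains open.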